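The source may report more compounds than this note shows. Statements on the series, on what has been measured and on what is new or still open speak of the compounds shown alone.

Compound 1 `[O-][n+]1cccc(Oc2ccccc2)c1`: 100 mg/kg
Compound 2 `Cc1c(Oc2ccccc2)ccc[n+]1[O-]`: 300 mg/kg

In a functional assay on the whole organism with Mus musculus as the target, in the maximal electroshock model, with a stated time of 30 min (a lower number here means that less compound is needed, a higher number that more compound is needed for the effect), compound 1 holds the lowest of the two numbers. Going by the values given here, the only measured step is a 3.0-fold higher number from compound 1 to compound 2 (0.48 log units; beyond the scatter), a methyl in place of hydrogen on an aromatic carbon. Compound 3 `O=Cc1cc[n+]([O-])cc1Oc1ccccc1` departs from compound 1 by formyl in place of hydrogen on an aromatic carbon. The methyl step bears on this only loosely, since formyl is another group at another place, and it suggests that adding a substituent gives a modestly higher number. A small rise, or none beyond the scatter, is therefore expected, a 1.5-fold higher number from compound 1 to compound 3 (0.18 log units; within the scatter). Compound 3 is estimated at 150 mg/kg, in the range 50 mg/kg to 450 mg/kg.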

Compound 3, minimum effective dose: 300 mg/kg
Compound 3: the middle estimate sits 2.0-fold (0.30 log units) below what was measured; the range from low to high includes it.
By their numbers in this assay, from the lowest: compound 1; then compounds 2 and 3 (each within the scatter of the next).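

In this assay, formyl on the aromatic carbon opposite the ring nitrogen gives a 3.0-fold higher number from compound 1 to compound 3 (0.48 log units; beyond the scatter), so substitution at this carbon also moves the number upward from that of compound 1. Compound 1 therefore keeps the lowest number of the three, and both single additions to it, at their different places, raise the number beyond the scatter. Nothing measured here accounts for this rise.

Going by these compounds, whether the rise belongs to formyl or to this carbon remains open. An amine or a carboxylic acid at the same place could separate the two.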